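This account rests on a few compounds, and the source may have more. Where it says the series, first, only, none or still open, it means among the compounds named here.

Measured compounds:
compound 1, `COc1nc2ccc(Br)cc2cc1C(c1ccccc1)n1cc(-c2ccccc2)nn1`, 5.97% in an ADME assay on PC-3 cells (Homo sapiens) for cytotoxicity, read by sulforhodamine B assay, with a stated time of 48 h, tested at 10 uM; a lower number here means less inhibition, a higher number more inhibition at the concentration tested (going by the name of the read-out)
compound 2, `CCOC(=O)c1cn(C(c2ccccc2)c2cc3cc(Br)ccc3nc2OC)nn1`, 16.1% in this assay

Among the compounds with values here, compound 2 stands highest of the two numbers in this assay, and the only measured step, a number 10.1 percentage points higher from compound 1 to compound 2 (beyond the scatter), lies beyond the scatter. Compound 3 `CCCCCc1cn(C(c2ccccc2)c2cc3cc(Br)ccc3nc2OC)nn1` has not been measured. It differs from compound 2 in one place: pentyl in place of ethoxycarbonyl on an aromatic carbon.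

Within the data shown here, the one step that bears on this change is a number 10.1 percentage points higher from compound 1 to compound 2 (beyond the scatter), which put ethoxycarbonyl in place of phenyl on the same aromatic carbon. Among the measured compounds shown here, it shows that the group at that position can shift the number beyond the scatter, but no measured compound carries pentyl there, so the direction for compound 3 is not fixed. Compound 3 is therefore expected to stay close to compound 2, at an estimated 14%, with a range from 2% to 28%. From compound 2 the expected step is a number 2.1 percentage points lower from compound 2 to compound 3 (within the scatter), within the scatter.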

Compound 3, a percentage reported as inhibition, at one concentration (the size of the read-out at that concentration, not a potency): 11.4%
Compound 3: the middle estimate sits 2.6 percentage points above what was measured; measured number inside the range.
By their numbers in this assay, from the lowest: compounds 1, 3 and 2 (each within the scatter of the next, the first and the last beyond it).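

Swapping ethoxycarbonyl for pentyl on this carbon of the triazole removes both hydrogen-bond acceptors and the double bond of the group, yet in this assay the change gives a number 4.7 percentage points lower from compound 2 to compound 3 (within the scatter) and so does not separate the two groups. Pentyl in place of phenyl gives a number 5.4 percentage points higher from compound 1 to compound 3 (within the scatter) and does not separate those two groups either, which leaves the pair of phenyl and ethoxycarbonyl as the only one of the three pairs to differ beyond the scatter. Nothing among the available data accounts for these numbers.

Going by these compounds, whether an amine, a carboxylic acid or a longer chain on this carbon would stand apart from pentyl remains open. So does whether these three groups would still compare in the same way on a core with something other than the phenyl or the methoxy group.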